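The compounds below may be only part of what the source reports. "The series", "measured", "known", "first", "only" and "open" are said of these compounds alone.

The measured compounds:

Compound 1 `O=[N+]([O-])c1cccc(NC(=S)NCCNS(=O)(=O)c2ccc(-c3ccccc3OCc3ccccc3)s2)c1` gives > 50000 nM, which is a limit of the assay rather than a number.
Compound 2 `O=C(NCCNS(=O)(=O)c1ccc(-c2ccccc2OCc2ccccc2)s1)Nc1cc(Cl)cc(Cl)c1` gives 11700 nM.
Compound 3 `Cc1ccc(-c2ccsc2S(=O)(=O)NCCNC(=O)Nc2cc(Cl)cc(Cl)c2)c(Oc2ccc(O)c(O)c2)c1` gives 3500 nM.

All three were tested in a functional assay on HL-60 cells (Homo sapiens) for inhibition, read by CCK-8 assay, with a stated time of 48 h; a lower number here means a stronger inhibitor, a higher number a weaker inhibitor. Compound 2 and compound 1 share a core and differ in one place: a group of 12 heavy atoms (7 carbon, 2 nitrogen, 2 oxygen, 1 sulfur; one six-membered aromatic ring of carbon only) in place of a group of 11 heavy atoms (7 carbon, 1 nitrogen, 1 oxygen, 2 chlorine; one six-membered aromatic ring of carbon only), on an amine nitrogen. This change gave an at least 4.2-fold higher number from compound 2 to compound 1 (0.63 log units; beyond the scatter), and the size of that step is known only as a lower bound because of the limit of > 50000 nM in this assay, at which 1 of the 3 values shown sits. Compound 3 differs from compound 2 in more than one place, and the difference between the two cores is not broken down here; what the two values show is that compound 3 gives the lower number in this assay, and that gap lies beyond the usual scatter.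

Compound 4 `Cc1ccc(-c2ccsc2S(=O)(=O)NCCNC(=S)Nc2cccc([N+](=O)[O-])c2)c(Oc2ccc(O)c(O)c2)c1` is not yet measured. It is related to compound 3 by a group of 12 heavy atoms (7 carbon, 2 nitrogen, 2 oxygen, 1 sulfur; one six-membered aromatic ring of carbon only) in place of a group of 11 heavy atoms (7 carbon, 1 nitrogen, 1 oxygen, 2 chlorine; one six-membered aromatic ring of carbon only), on an amine nitrogen, and since the place of the change is described in the same words as for the step from compound 2 to compound 1, this is the same change made on the core of compound 3. Among the compounds shown this change occurs twice in all, and the one measured instance is the step from compound 2 to compound 1. Resting on an at least 4.2-fold higher number from compound 2 to compound 1 (0.63 log units; beyond the scatter), compound 4 is expected to show a step of about a 5.7-fold higher number from compound 3 to compound 4 (0.76 log units; beyond the scatter) in this assay, with the added uncertainty that the earlier step is itself only a lower bound. Compound 4 is therefore estimated at 20000 nM, with a plausible range from 8000 nM to 60000 nM.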

Compound 4, half-maximal inhibitory concentration: 3400 nM
Beside the measured number, compound 4's estimate is 5.9-fold (0.77 log units) above it; the whole stated range lies above it.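

On the core of compound 3, replacing the (3,5-dichlorophenyl)carbamoyl group on the amine nitrogen with the entering group of 12 heavy atoms gave a 1.0-fold lower number from compound 3 to compound 4 (0.01 log units; within the scatter) in this assay, so the two values cannot be told apart. The change therefore did not carry over from one core to the other with the same size of step: the same change on two cores in this assay, an at least 4.2-fold higher number (0.63 log units; beyond the scatter) from compound 2 to compound 1 and a 1.0-fold lower number (0.01 log units; within the scatter) from compound 3 to compound 4, at least 4.3-fold (0.64 log units) apart, beyond the scatter of two such steps Compound 1 sits at a limit of the assay, so the earlier step is known only as a lower bound, and the pair shows that the outcome of this change depends on the core in this series, not how large the gap truly is or how the change would behave on any third core: the limit of > 50000 nM in this assay, at which 1 of the 4 values shown sits.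

The cores of compound 2 and compound 3 differ in more than one place, which leaves open which of those differences accounts for the two steps. As far as these compounds go, the entering group also brings in a sulfur in place of the carbonyl oxygen and a nitro group in place of the two chlorines in a single change, so the part each plays remains open, as does the result with a simple amine on that aromatic ring.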